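Dithiocarbamate series: amine variation at the thiocarbonyl carbon

This account rests on a few compounds, and the source may have more. Where it says the series, first, only, none or still open, it means among the compounds named here.

Working notes on three measured dithiocarbamates sharing one core, followed by an expectation for a fourth. Compound 1 `CCN(CC)C(=S)SCC1=CCOC1=O` gives 1390 nM in a functional assay on HeLa cells (Homo sapiens) for antiproliferative activity, read by MTT assay, with a stated time of 72 h; on this read-out higher numbers stand for weaker inhibition and lower numbers for stronger inhibition. Compound 2 `CCNC(=S)SCC1=CCOC1=O` is reported in this assay as "not active" (no number reported), with no single number attached. Compound 3 `CN(C)C(=S)SCC1=CCOC1=O` gives 114000 nM in this assay and so stands highest of the two numbers available; its nearest neighbour is compound 1, reached through an 82-fold higher number from compound 1 to compound 3 (1.91 log units; beyond the scatter), a large step that lies beyond the scatter.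

Compound 4 `CC(C)NC(=S)SCC1=CCOC1=O` differs from compound 3 by isopropylamino in place of dimethylamino on a thiocarbonyl carbon. Two of the measured entries bear on this. The step of an 82-fold higher number from compound 1 to compound 3 (1.91 log units; beyond the scatter) shows that shrinking the dialkylamino group raises the number sharply, so the size of the alkyl portion matters in this position. Compound 2, which also carries a hydrogen-bond donor on its nitrogen, was "not active" (no number reported), which points toward a high chance that compound 4 likewise yields no number in this assay. Where a number is obtained, the expected step is a 1.8-fold higher number from compound 3 to compound 4 (0.24 log units; within the scatter), toward a higher number. The estimate for compound 4 in this assay is therefore 200000 nM, with a range from 50000 nM to 800000 nM.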

Compound 4, half-maximal inhibitory concentration: 137000 nM
Estimate against measurement, compound 4: 1.5-fold (0.16 log units) above; the measured number falls inside the stated range.
By their numbers in this assay, from the lowest: compound 1; then compounds 3 and 4 (each within the scatter of the next).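

In this assay, isopropylamino in place of dimethylamino on a thiocarbonyl carbon gives a 1.2-fold higher number from compound 3 to compound 4 (0.08 log units; within the scatter), so neither the additional heavy atom nor the hydrogen-bond donor of the entering group separates compound 4 from compound 3 on this read-out. Against diethylamino the same group gives a 99-fold higher number from compound 1 to compound 4 (1.99 log units; beyond the scatter), which leaves compound 1 as the only low number among the three measured compounds, while compound 4 carries a number where compound 2 has none, showing that a hydrogen-bond donor on this nitrogen does not by itself go with the absence of a number. No measurement at hand gives a reason for any of these differences.

Still open, on these data alone, is whether the low number of compound 1 belongs to diethylamino alone or extends to longer chains on the nitrogen, such as dipropylamino, or to a cyclic amine such as piperidine. Ethylmethylamino on the thiocarbonyl carbon would also show whether a single ethyl chain on a nitrogen without a hydrogen-bond donor is enough to move the number away from that of compound 3.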